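Alkyl chain length and tolerated concentration on two cores

A few compounds are considered here, and "the series" means these few. Any claim that something is new, unique, unknown or untested is made for them only; others in the source may bear on it.

Measured compounds:
- compound 1, `CCCCNc1cnc(C(=O)NCc2ccccc2)cn1`: 100000 nM
- compound 2, `CCCCCCCCNc1cnc(C(=O)NCc2ccccc2)cn1`: >= 20000 nM, a limit of the assay rather than a number
- compound 3, `CCCCNc1cncc(C(=O)NCc2ccccc2)n1`: 100000 nM

All three were tested in an ADME assay on MDCK cells (Canis lupus familiaris) for cytotoxicity, read by microscopy, with a stated time of 6 days; a higher number here means that more compound is tolerated, a lower number that less compound is tolerated. Compound 1 gives 100000 nM. Compound 3 gives 100000 nM, level with compound 1 within the scatter. Compound 3 and compound 1 have the same atoms joined differently; the difference between the two cores is not broken down here.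

Compound 2 is reported only as a limit, >= 20000 nM. The change from compound 1 to compound 2 is butyl in place of hydrogen on a saturated chain carbon, four bonds along the chain from a nitrogen on an aromatic ring, and the step it made is a step that the limit leaves unreadable from compound 1 to compound 2, so its size cannot be read, due to the limit of >= 20000 nM in this assay, at which 1 of the 3 values shown sits.

Compound 4, `CCCCCCCCNc1cncc(C(=O)NCc2ccccc2)n1`, is not yet measured. It differs from compound 3 by butyl in place of hydrogen on a saturated chain carbon, four bonds along the chain from a nitrogen on an aromatic ring, the same change as from compound 1 to compound 2, at the same place. Compound 3 gives 100000 nM, where compound 1 also sits. The outcome for compound 4 is therefore expected to resemble that of compound 2. The limit reported for compound 2 leaves the true size open. Compound 4 is estimated at 40000 nM, with a range from 15000 nM to 100000 nM. The step this estimate implies is a 2.5-fold lower number from compound 3 to compound 4 (0.40 log units; beyond the scatter), expected rather than known.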

Compound 4, minimum cytotoxic concentration: 4000 nM
Beside the measured number, compound 4's estimate is 10-fold (1.00 log units) above it; measured number below the stated range.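

On the core of compound 3, butyl in place of hydrogen on a saturated chain carbon, four bonds along the chain from a nitrogen on an aromatic ring, gives a 25-fold lower number from compound 3 to compound 4 (1.40 log units; beyond the scatter) in this assay, so the longer chain on this core goes with much less compound being tolerated. The same change on the core of compound 1 cannot be read as a step, due to the limit that compound 2 reaches: the limit of >= 20000 nM in this assay, at which 1 of the 4 values shown sits. Compound 2 is reported as >= 20000 nM, which is a limit and not a number, so the result shows a large step on one core only and does not show that the change has the same size on both cores.

The compounds shown leave open whether the tolerated concentration falls gradually or all at once between the two chain lengths on the core of compound 3, as a hexyl chain might tell, and whether a still longer chain would go lower. They also leave open how a chain carrying a carboxylic acid or an amine would behave in this assay.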